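A Shorter Arm on the Shared Core: Compound 4

The source may report more compounds than this note shows. Statements on the series, on what has been measured and on what is new or still open speak of the compounds shown alone.

Compound 1 `c1ccc(CN(CCCCN(C[C@H]2Cc3ccccc3CN2)[C@H]2CCCc3cccnc32)Cc2ccccn2)nc1`: in a functional assay on cells for agonist activity at C-X-C chemokine receptor type 4 (Homo sapiens), read by fluorescence and calcium flux, with a stated time of 90 s (on this read-out lower numbers stand for an effect already at smaller amounts and higher numbers for an effect only at larger amounts of compound), compound 1 gives > 30000 nM, which is a limit of the assay and not a number.
Compound 2 `c1cncc(CNCCCCN(C[C@H]2Cc3ccccc3CN2)[C@H]2CCCc3cccnc32)c1`: in this assay compound 2 gives > 30000 nM, again a limit rather than a number.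
Compound 3 `c1ccc(CNCCCCN(C[C@H]2Cc3ccccc3CN2)[C@H]2CCCc3cccnc32)cc1`: in this assay compound 3 gives > 30000 nM, also a limit.

Compound 2 therefore stands at a limit, with no number of its own, and the two other values shown are limits as well, so nothing here ranks it against compound 1 or compound 3. Among the measured compounds shown here, the only single-point step among the measured compounds, a step that the two limits leave unreadable from compound 2 to compound 3, is unreadable in size because both of its ends are limits. Compound 4 `NCc1ccccc1CN(C[C@H]1Cc2ccccc2CN1)[C@H]1CCCc2cccnc21` differs from compound 2 by 2-(aminomethyl)phenyl in place of 3-(((pyridin-3-yl)methyl)amino)propyl on a saturated chain carbon bound to an amine nitrogen. For the measured compounds named here, no measured step bears on this change directly; the one step available cannot be read, and the limit of > 30000 nM in this assay, at which 3 of the 3 values shown sit, is the whole of the evidence. With nothing readable to lean on, no direction beyond the scatter is expected, and a further limit is the likeliest outcome. The step from compound 2 to compound 4 is expected to be about an at least 1.5-fold lower number from compound 2 to compound 4 (0.17 log units; that floor lies within the scatter). Compound 4 is estimated at 20000 nM, within a range from 2000 nM to 100000 nM.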

Compound 4, half-maximal effective concentration: > 30000 nM
Compound 4: a limit, no number; the forecaster's own chance of this, stated with the estimate: 65%; middle value at least 1.5-fold (0.17 log units) away from the limit.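

In this assay compound 4 gives > 30000 nM, which is a limit and not a number. The steps to compound 4 from compound 2 and from compound 3 therefore cannot be read. How these four compounds rank against one another stays open, because the record so far comes down to this: the limit of > 30000 nM in this assay, at which 4 of the 4 values shown sit.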